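This account rests on a few compounds, and the source may have more. Where it says the series, first, only, none or still open, it means among the compounds named here.

Three compounds share one core. Compound 1 `COc1cc(C)cc(-c2nn(CC#N)cc2-c2ccc(-c3cccc(C(C)=O)c3)nc2)c1` gives 9% in a functional assay on K562 cells (Homo sapiens) for cytotoxicity, read by sulforhodamine B assay, with a stated time of 48 h, tested at 10 uM; a higher number here means a weaker effect of the compound at the concentration tested, a lower number a stronger effect. Compound 2 `Cc1cc(O)cc(-c2nn(CC#N)cc2-c2ccnc(-c3ccc(Oc4ccccc4)cc3)c2)c1` gives -2% in this assay, and compound 3 `COc1cc(C)cc(-c2nn(CC#N)cc2-c2ccnc(-c3ccc(N(C)C)cc3)c2)c1` gives 3% in this assay. Compound 3 stands second highest of the three numbers, yet it lies within the scatter of both compound 2 and compound 1, so none of the three can be set apart. Compound 4 `Cc1cc(O)cc(-c2nn(CC#N)cc2-c2ccnc(-c3ccc(N(C)C)cc3)c2)c1` has not yet been measured; it differs from compound 3 by hydrogen in place of methyl on an oxygen on an aromatic ring. Because compound 2 with its hydroxy group gives -2% in this assay and sits within the scatter of compound 3, the expected step is a number 1 percentage points lower from compound 3 to compound 4 (within the scatter), nothing beyond the scatter. Compound 4 is therefore estimated at 2%, in a range from -8% to 12%.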

Compound 4, a percentage reported as activity, at one concentration (the size of the read-out at that concentration, not a potency): -6%
Compound 4: the middle estimate sits 8 percentage points above what was measured; the range from low to high includes it.
By their numbers in this assay, from the lowest: compounds 4, 2, 3 and 1 (each within the scatter of the next, the first and the last beyond it).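

In this assay, among the compounds shown here, hydrogen in place of methyl on an oxygen on an aromatic ring gives a number 9 percentage points lower from compound 3 to compound 4 (within the scatter) and is the first direct reading of this change, so methoxy and hydroxy cannot be told apart here. Dimethylamino in place of phenoxy on an aromatic carbon gives a number 4 percentage points lower from compound 2 to compound 4 (within the scatter) and likewise stays inside the scatter. No measurement shown here offers an explanation for either step. As far as these compounds go, it remains open whether ethoxy or benzyloxy in place of the hydroxy would move the number beyond the scatter. The same holds for an amine or a carboxylic acid at that place.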